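The source may report more compounds than this note shows. Statements on the series, on what has been measured and on what is new or still open speak of the compounds shown alone.

Compound 2 `CCCCC(C(=O)OC)N1C(=O)/C(=C/c2ccc(C(=O)N[C@@H](CCCNC(=N)N)C(=O)N[C@@H](CCCCN)C(=O)N[C@@H](CCCC)C(N)=O)cc2)SC1=S` gives 0.87 10^-6 cm/s in an ADME assay for permeability, using PAMPA; a lower number here means that the compound crosses the layer more slowly, a higher number that the compound crosses the layer faster. Compound 1 `CCCC[C@H](NC(=O)[C@H](CCCCN)NC(=O)[C@H](CCCNC(=N)N)NC(=O)/C=C/c1ccccc1)C(N)=O` gives 1.26 10^-6 cm/s in this assay, a number within the usual scatter of that of compound 2, so the two cannot be told apart on these measurements. Compound 3 `CCCC[C@H](NC(=O)[C@H](CCCCN)NC(=O)[C@H](CCCNC(=N)N)NC(=O)c1ccc(/C=C2\SC(=S)N(C3CCCCC3)C2=O)cc1)C(N)=O` has not yet been measured in this assay. It differs from compound 2 by cyclohexyl in place of 1-(methoxycarbonyl)pentyl on an amide-type nitrogen in a ring. Among the compounds with values here, no measured pair shows a change of this kind, so the data give no direct guide. The expected step is a 1.3-fold higher number from compound 2 to compound 3 (0.10 log units; within the scatter), small and in no clear direction. Compound 3 is estimated at 1.1 10^-6 cm/s, with a range from 0.5 10^-6 cm/s to 2.5 10^-6 cm/s.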

Compound 3, apparent permeability: 1.82 10^-6 cm/s
The estimate for compound 3 lay 1.7-fold (0.22 log units) below the measured number, and the stated range covers the measured number.
By their numbers in this assay, from the lowest: compounds 2, 1 and 3 (each within the scatter of the next, the first and the last beyond it).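

Cyclohexyl in place of 1-(methoxycarbonyl)pentyl on the amide-type nitrogen in the ring gives a 2.1-fold higher number from compound 2 to compound 3 (0.32 log units; beyond the scatter) in this assay and this modest step is the first here to lie beyond the scatter. The group at this position can therefore shift the read-out, which the gap between compound 1 and compound 2 could not show. The swap removes the methoxycarbonyl and adds a ring in one move, so their shares stay unseparated. How a carboxylic acid or a phenyl ring would read here remains open, and no measurement at hand explains the step.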